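From 4-fluorophenyl to 4-bromophenyl: working notes

The compounds below may be only part of what the source reports. "The series", "measured", "known", "first", "only" and "open" are said of these compounds alone.

In a functional assay on HeLa cells (Homo sapiens) for antiproliferative activity, read by MTT assay, with a stated time of 72 h (on this read-out lower numbers stand for stronger inhibition and higher numbers for weaker inhibition), compound 1 (`COc1cc(-c2nccn2C(C)C)cc(OC)c1OC`) gives > 100000 nM, which is a limit of the assay and not a number. For the measured compounds named here, compound 2 (`COc1cc(-c2nccn2-c2ccc(F)cc2)cc(OC)c1OC`) gives 17500 nM, the only actual number so far. Going by the values given here, the one measured step, an at least 5.7-fold lower number from compound 1 to compound 2 (0.75 log units; beyond the scatter), is 4-fluorophenyl in place of isopropyl on an aromatic nitrogen, and it starts from the limit of > 100000 nM in this assay, at which 1 of the 2 values shown sits. Compound 3 (`COc1cc(-c2nccn2-c2ccc(Br)cc2)cc(OC)c1OC`) differs from compound 2 by bromo in place of fluoro on an aromatic carbon. The change is bromo in place of fluoro on an aromatic carbon, para to a large group. The measured step concerns a different change, so it sets no size for this one. No step beyond the scatter is therefore expected in this assay. The expected step is a 1.2-fold lower number from compound 2 to compound 3 (0.07 log units; within the scatter). Compound 3 is estimated at 15000 nM, with an expected range of 5000 nM to 50000 nM.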

Compound 3, half-maximal inhibitory concentration: 3300 nM
Estimate against measurement, compound 3: 4.5-fold (0.66 log units) above; measured number below the stated range.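

Bromo in place of fluoro on this aromatic carbon, para to a large group, gives a 5.3-fold lower number from compound 2 to compound 3 (0.72 log units; beyond the scatter) in this assay, so this position responds to the exchange of one heavy atom for another, with no hydrogen-bond donor or acceptor entering or leaving. With the 4-bromophenyl group, the replacement of isopropyl on the aromatic nitrogen reads as an at least 30-fold lower number from compound 1 to compound 3 (1.48 log units; beyond the scatter), and that size is only a bound: the limit of > 100000 nM in this assay, at which 1 of the 3 values shown sits. Compound 3 is the most potent of the three compounds shown, with its steps to both others beyond the scatter.

The compounds shown leave open how chloro, iodo or an amine on this carbon would read. With only two substituents compared here, they also give no reason for the step and no trend that could be extended beyond this pair.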